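What Losing One Methyl Might Do to Compound 2

The source may report more compounds than this note shows. Statements on the series, on what has been measured and on what is new or still open speak of the compounds shown alone.

Among the measured compounds shown here, two related compounds have numbers so far. In a functional assay on MIA PaCa-2 cells (Homo sapiens) for antiproliferative activity, read by sulforhodamine B assay, with a stated time of 48 h (on this read-out lower numbers stand for stronger inhibition and higher numbers for weaker inhibition), compound 1 `COc1ccc(C(=O)/C=C\Nc2ccc(-c3nc4cc(OC)c(OC)c(OC)c4s3)cc2)cc1[N+](=O)[O-]` gives 15900 nM, and compound 2 `COc1cc(C(=O)/C=C\Nc2ccc(-c3nc4cc(OC)c(OC)c(OC)c4s3)cc2C)cc(OC)c1OC` gives 22800 nM. These two values lie within the usual scatter of each other, so compound 2 stands level with compound 1, and neither can be ranked above the other. Both numbers sit in a range that means only modest inhibition of cell growth.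

The next compound, compound 3 `COc1cc(C(=O)/C=C\Nc2ccc(-c3nc4cc(OC)c(OC)c(OC)c4s3)cc2)cc(OC)c1OC`, is compound 2 with hydrogen in place of methyl on an aromatic carbon. The change sits on the ring that carries the large group of the shared core. For the measured compounds named here, no pair of measured compounds differs in a single place, so the data offer no direct guide to what this swap does. In this assay, a small shift towards a lower number is expected, though not one beyond the scatter. The estimated step is a 1.4-fold lower number from compound 2 to compound 3 (0.15 log units; within the scatter). For compound 3, the expected value is 16000 nM, with an estimated range of 5000 nM to 40000 nM.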

Compound 3, half-maximal inhibitory concentration: 29100 nM
The estimate for compound 3 lay 1.8-fold (0.26 log units) below the measured number; the measured number falls inside the stated range.
By their numbers in this assay, from the lowest: compounds 1, 2 and 3 (each within the scatter of the next).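

In this assay, the first single-place comparison gives a 1.3-fold higher number from compound 2 to compound 3 (0.11 log units; within the scatter) when hydrogen replaces methyl on this aromatic carbon, ortho to a large group and meta to a large group, so on this evidence the methyl cannot be said to matter in either direction. The second comparison concerns the other end of the molecule: 3,4,5-trimethoxyphenyl in place of 4-methoxy-3-nitrophenyl on a carbonyl carbon gives a 1.8-fold higher number from compound 1 to compound 3 (0.26 log units; within the scatter) and so cannot be told apart from repeat-to-repeat variation either, which means that neither of the two swaps separates the compounds in this cell test. Nothing measured alongside these numbers offers an explanation for them.

Only hydrogen and methyl can be compared on this aromatic carbon, so a single small swap says little about the position as a whole, and an amine or a carboxylic acid placed there could behave quite differently. From the compounds shown here alone, it also remains open whether any other group at this position, or on the ring at the carbonyl end, could move the number beyond the usual scatter.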